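Benzoxazole sulfonamides: cytotoxicity, from compound 1 to compound 4

The source may hold more compounds than are shown below. What is called first, only, known or untested is meant among the compounds shown, and "the series" means these compounds.

Measured so far in an ADME assay on HEK293 cells (Homo sapiens) for cytotoxicity, read by resazurin assay, with a stated time of 48 h; a lower number here means that less compound is tolerated, a higher number that more compound is tolerated:
compound 1, `COc1ccc(Cl)cc1S(=O)(=O)Nc1ccc(-c2nc3ccccc3o2)cc1`: 75000 nM
compound 2, `O=S(=O)(Nc1ccc2oc(-c3ccccc3)nc2c1)c1cccc(O)c1`: > 100000 nM
compound 3, `O=[N+]([O-])c1cc(S(=O)(=O)Nc2ccc3oc(-c4ccccc4)nc3c2)ccc1Cl`: 90000 nM

Compound 1 gives the lowest of the two numbers in hand, 75000 nM. Its nearest neighbour is compound 3 at 90000 nM, a gap within the usual scatter, so the two cannot be told apart. For compound 2 the read-out is a limit and not a number: compound 2 sits at the limit of > 100000 nM in this assay, at which 1 of the 3 values shown sits. All three measured compounds are therefore only weakly cytotoxic in this assay.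

Compound 4, `Cc1ccc(S(=O)(=O)Nc2ccc(-c3nc4ccccc4o3)cc2)cc1`, is not yet measured. It differs from compound 1 in one place: 4-methylphenyl in place of 5-chloro-2-methoxyphenyl on a sulfonyl sulfur. Within the data shown here, no measured pair carries this change, so nothing in the set sets its size. Since every measured value lies in the same weak region, no step beyond the scatter is expected in this assay for compound 4, in either direction. The expected step is a 1.1-fold higher number from compound 1 to compound 4 (0.05 log units; within the scatter). Compound 4 is estimated at 85000 nM, with a range of 40000 nM to 200000 nM.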

Compound 4, half-maximal cytotoxic concentration: 88000 nM
Compound 4: the middle estimate sits 1.0-fold (0.02 log units) below what was measured; the range from low to high includes it.
By their numbers in this assay, from the lowest: compounds 1, 4 and 3 (each within the scatter of the next). At a limit, above all of these: compound 2.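

In this assay the position on the sulfonyl sulfur now carries a measured one-place change, and a 1.2-fold higher number from compound 1 to compound 4 (0.07 log units; within the scatter) stands as its size. Exchanging 5-chloro-2-methoxyphenyl for 4-methylphenyl removes the chlorine and the oxygen of the leaving group, yet gives no step that can be separated from the scatter, so neither atom can be shown to matter here on this pair alone. Compound 2 remains a limit and not a number: the limit of > 100000 nM in this assay, at which 1 of the 4 values shown sits.

Still open, going by these compounds, is whether an amine or a carboxylic acid on this aromatic ring, or a longer chain in its place on the sulfonyl sulfur, would give a step beyond the scatter. Also open, on these data alone, is whether this one pair carries over to the core of compound 2 and compound 3.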